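Swapping the Aryl Group on the Core of Compound 1

The source may hold more compounds than are shown below. What is called first, only, known or untested is meant among the compounds shown, and "the series" means these compounds.

Compound 1 `CS(=O)(=O)c1ccc(-n2c(=O)n(Cc3cc4cc(Cl)ccc4n3CCCC#N)c3cnccc32)cc1` carries a 4-(methylsulfonyl)phenyl group on an aromatic nitrogen of its shared core. In an ADME assay on HeLa cells (Homo sapiens) for cytotoxicity, read by ATP content, with a stated time of 3 days (a lower number here means that less compound is tolerated, a higher number that more compound is tolerated), compound 1 gives > 50000 nM, a limit of the assay rather than a number. Compound 2 `O=C(O)CCCn1c(Cn2c(=O)n(C3CC3)c3ccncc32)cc2cc(Cl)ccc21` likewise reaches only a limit in this assay, > 50000 nM. Compound 3 `O=c1n(Cc2cc3cc(Cl)ccc3n2CCCCF)c2cnccc2n1C1CC1` also gives a limit in this assay, > 50000 nM. For the measured compounds named here, the single measured step, a step that the two limits leave unreadable from compound 2 to compound 3, is unreadable because the limit of > 50000 nM in this assay, at which 3 of the 3 values shown sit, holds both of its ends. Compound 4 `N#CCCCn1c(Cn2c(=O)n(-c3ncccn3)c3ccncc32)cc2cc(Cl)ccc21` differs from compound 1 by pyrimidin-2-yl in place of 4-(methylsulfonyl)phenyl on an aromatic nitrogen. Going by the values given here, no measured step speaks to this change, so no shift beyond the scatter is expected. Compound 4 is therefore estimated at 60000 nM, between 25000 nM and 150000 nM, most likely again reported as a limit. The implied step, a step that the limit leaves unreadable from compound 1 to compound 4, is expected to stay within the scatter.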

Compound 4, half-maximal cytotoxic concentration: > 50000 nM
Compound 4: only a limit was reported; the forecaster's own chance of this, stated with the estimate: 85%; the middle value is on the limit's open side.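

The step from compound 1 to compound 4 cannot be read, as both of its ends are limits of the assay: the limit of > 50000 nM in this assay, at which 4 of the 4 values shown sit.

The compounds shown leave open whether any change on the shared core would give a readable number in this assay.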